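The source may report more compounds than this note shows. Statements on the series, on what has been measured and on what is new or still open speak of the compounds shown alone.

Values measured in an ADME assay on CHO cells (Cricetulus griseus) for cytotoxicity, read by MTT assay; on this read-out lower numbers stand for stronger inhibition and higher numbers for weaker inhibition:
- Compound 1 `O=C(/C=C/c1ccc(O)c(CN2CCCCC2)c1)c1ccc(C(F)(F)F)cc1`: 8220 nM
- Compound 2 `O=C(/C=C/c1ccc(CN2CCCCC2)c(O)c1)c1ccc(Br)cc1`: 7270 nM
- Compound 3 `CCc1ccc(C(=O)/C=C/c2ccc(CN3CCCCC3)c(O)c2)cc1`: 6590 nM

Compound 2, at 7270 nM, cannot be separated from the other two compounds, since all three values lie within the usual scatter of one another. The next compound to be tested is compound 4 `O=C(/C=C/c1ccc(CN2CCCCC2)c(O)c1)c1ccc(F)cc1`, which keeps the core of compound 2 and changes one group: fluoro in place of bromo on an aromatic carbon. In words, this is fluoro in place of bromo on an aromatic carbon, turning 4-bromophenyl into 4-fluorophenyl.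

For the measured compounds named here, only one measured step bears directly on this change: a 1.1-fold lower number from compound 2 to compound 3 (0.04 log units; within the scatter). It replaces the same bromo group, with ethyl rather than fluoro, and leaves the number essentially unmoved. Compound 1 differs from compound 2 in more than one place, so it offers no clean comparison. Going by the values given here, no fluoro compound has been measured yet, so this evidence is thin. A step beyond the scatter is therefore not expected in this assay. The expected change is a 1.0-fold higher number from compound 2 to compound 4 (0.01 log units; within the scatter). For compound 4 the estimated value is 7500 nM, with an expected range from 4500 nM to 12500 nM.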

Compound 4, half-maximal inhibitory concentration: 77300 nM
The estimate for compound 4 lay 10-fold (1.01 log units) below the measured number, and the stated range ends below it.
By their numbers in this assay, from the lowest: compounds 3, 2 and 1 (each within the scatter of the next); then compound 4.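

In this assay the group on this aromatic carbon turns out to matter: fluoro in place of bromo gives an 11-fold higher number from compound 2 to compound 4 (1.03 log units; beyond the scatter) and fluoro in place of ethyl gives a 12-fold higher number from compound 3 to compound 4 (1.07 log units; beyond the scatter) while ethyl in place of bromo gave only a 1.1-fold lower number from compound 2 to compound 3 (0.04 log units; within the scatter). Bromo and ethyl therefore cannot be told apart here, whereas fluoro stands clearly apart from both, with the higher number that means weaker inhibition. Nothing at hand explains why exchanging one halogen atom for another has so large an effect.

From the compounds shown here alone, it remains open whether fluoro is a lone case or whether chloro or methoxy on the same carbon would also give a number far from those of compound 2 and compound 3. Also open, going by these compounds, is whether the same change would act alike on the core of compound 1.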